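Aryl swap on the piperidine amide: compound 2 to compound 4

The compounds below may be only part of what the source reports. "The series", "measured", "known", "first", "only" and "open" are said of these compounds alone.

Three compounds share one core and differ only in the aryl group on the ring nitrogen. In an assay on HEK293 cells for displacement of a labelled ligand from transient receptor potential cation channel subfamily V member 1 (Homo sapiens) (a higher number here means a weaker inhibitor, a lower number a stronger inhibitor), compound 1 `O=C1COc2ccc(NC(=O)C3CCN(c4ccccc4Br)CC3)cc2N1` gives 71 nM. Compound 2 `CC(C)c1ccccc1N1CCC(C(=O)Nc2ccc3c(c2)NC(=O)CO3)CC1` gives 78 nM in this assay, which places it second highest of the three numbers, with compound 1 nearest and compound 3 furthest, both within the scatter. Compound 3 `O=C1COc2ccc(NC(=O)C3CCN(c4cccc(Cl)c4)CC3)cc2N1` gives 97 nM in this assay.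

The step to compound 4 `Cc1c(Cl)cccc1N1CCC(C(=O)Nc2ccc3c(c2)NC(=O)CO3)CC1` is 3-chloro-2-methylphenyl in place of 2-isopropylphenyl on an amine nitrogen in a ring. Among the compounds with values here, two measured steps bear on it, since both replace the aryl group at the same place: a 1.4-fold higher number from compound 1 to compound 3 (0.14 log units; within the scatter) and a 1.2-fold higher number from compound 2 to compound 3 (0.09 log units; within the scatter). The step of a 1.1-fold higher number from compound 1 to compound 2 (0.04 log units; within the scatter), a change within the aryl group, was likewise small. Every aryl change recorded here stayed inside the scatter, so for compound 4 no step beyond the scatter is expected in this assay, in either direction.

Compound 4 is therefore expected to give about 85 nM in this assay, with a plausible range from 40 nM to 180 nM. The corresponding expected step is a 1.1-fold higher number from compound 2 to compound 4 (0.04 log units; within the scatter), an estimate rather than a measurement.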

Compound 4, inhibition constant: 100 nM
Estimate against measurement, compound 4: 1.2-fold (0.07 log units) below; the range from low to high includes it.
By their numbers in this assay, from the lowest: compounds 1, 2, 3 and 4 (each within the scatter of the next).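

In this assay the change from 2-isopropylphenyl to 3-chloro-2-methylphenyl on the amine nitrogen in a ring gives a 1.3-fold higher number from compound 2 to compound 4 (0.11 log units; within the scatter) and the change from 2-bromophenyl to the same group gives a 1.4-fold higher number from compound 1 to compound 4 (0.15 log units; within the scatter) so this position has now held a group carrying both a chloro and a methyl substituent with no step beyond the scatter. The new pair also isolates a single added group, since methyl in place of hydrogen on an aromatic carbon gives a 1.0-fold higher number from compound 3 to compound 4 (0.01 log units; within the scatter) and adding this methyl to the 3-chlorophenyl group thus leaves the number within the scatter. Nothing available here bears on the reason for this result.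

Every aryl group shown carries only bromo, chloro, methyl or isopropyl, so it remains open whether an amine or a carboxylic acid on that aryl group would also stay within the scatter. On these data alone, the shared core and its amide are the same in all four compounds, so what a change there would do in this assay also remains open.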